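The source may hold more compounds than are shown below. What is called first, only, known or untested is meant among the compounds shown, and "the series" means these compounds.

Working notes on the series. Within the data shown here, in an assay on CHO cells with metabotropic glutamate receptor 5 (Homo sapiens) as the target (a lower number here means that less compound is needed, a higher number that more compound is needed for the effect), compound 1 `O=C(Nc1cc(-c2ccccc2)nn1-c1ccccc1)c1ccccc1F` gives 75 nM, the lowest of the two numbers so far; its nearest neighbour is compound 2 `O=C(Nc1cc(-c2ccccc2)nn1-c1ccccc1)c1ccsc1`, which in this assay gives 1800 nM. Among the measured compounds shown here, the only step measured so far, a 24-fold higher number from compound 1 to compound 2 (1.38 log units; beyond the scatter), shows that the aryl group on the carbonyl carbon matters greatly for this assay. Compound 3 `O=C(Nc1cc(-c2ccccc2)nn1-c1ccccc1)c1ccc(C(F)(F)F)cc1` differs from compound 1 in one place: 4-(trifluoromethyl)phenyl in place of 2-fluorophenyl on a carbonyl carbon. The measured step from compound 1 to compound 2 bears on this only loosely, since it swaps the six-membered ring for a different ring, whereas compound 3 keeps a six-membered aromatic ring of carbon only and changes the substituent. For the measured compounds named here, no measured pair shows what a 4-(trifluoromethyl)phenyl group does here. A moderate rise in the number is expected, a 4.0-fold higher number from compound 1 to compound 3 (0.60 log units; beyond the scatter), smaller than the measured step to compound 2. For compound 3 in this assay the estimate is 300 nM, expected between 60 nM and 2000 nM.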

Compound 3, half-maximal effective concentration: 19 nM
Compound 3: the middle estimate sits 16-fold (1.20 log units) above what was measured; the whole stated range lies above it.
By their numbers in this assay, from the lowest: compound 3; then compound 1; then compound 2.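

Swapping 2-fluorophenyl for 4-(trifluoromethyl)phenyl on the carbonyl carbon gives a 3.9-fold lower number from compound 1 to compound 3 (0.60 log units; beyond the scatter) in this assay, so this position accepts a group with more heavy atoms and the number still falls. Set against thiophen-3-yl, the same group gives a 95-fold lower number from compound 2 to compound 3 (1.98 log units; beyond the scatter) and now holds the lowest number of the three, which widens the range seen at this position and removes 2-fluorophenyl from the lead. No supporting data bear on this result.

The change alters both the substituent and the way it is printed on the ring, so the compounds shown do not separate the contribution of the trifluoromethyl group from that of its location. An unsubstituted phenyl, a 2-(trifluoromethyl)phenyl or a 4-fluorophenyl group on the same carbonyl carbon would be needed to tell these apart, and the other rings of the shared core remain unvaried here.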